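The source may report more compounds than this note shows. Statements on the series, on what has been measured and on what is new or still open speak of the compounds shown alone.

Of the compounds shown here, three sharing one core have been tested in a functional assay on U-251 cells (Homo sapiens) for cytotoxicity; on this read-out higher numbers stand for weaker inhibition of growth and lower numbers for stronger inhibition of growth. Compound 1 (`CSc1ccc(C2=C(c3ccc(C)c(C)c3)C(=O)N3CCCC3C2)cc1`) gives 10000 nM, compound 2 (`CSc1ccc(C2=C(c3ccc(F)c(C)c3)C(=O)N3CCCC3C2)cc1`) gives 200 nM, and compound 3 (`CSc1ccc(C2=C(c3ccc(O)c(O)c3)C(=O)N3CCCC3C2)cc1`) gives 30000 nM. Compound 3 therefore has the highest number of the three, which means the weakest inhibition of growth.

Compound 4 (`CSc1ccc(C2=C(c3ccc(Br)cc3)C(=O)N3CCCC3C2)cc1`) has not yet been measured. It differs from compound 3 as follows: 4-bromophenyl in place of 3,4-dihydroxyphenyl on a double-bonded ring carbon. This puts 4-bromophenyl in place of 3,4-dihydroxyphenyl on a double-bonded ring carbon.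

Two measured steps involve this same carbon: a 3.0-fold higher number from compound 1 to compound 3 (0.48 log units; beyond the scatter) and a 150-fold higher number from compound 2 to compound 3 (2.18 log units; beyond the scatter). Read backwards, both show that compound 3 lies above the two compounds without the 3,4-dihydroxyphenyl group, by a modest gap in one case and a large gap in the other. The third step, a 50-fold lower number from compound 1 to compound 2 (1.70 log units; beyond the scatter), shows that a single fluoro in place of methyl can shift the number greatly. Among the compounds with values here, no measured compound carries bromine, so these steps give the direction better than the size. A large move towards a lower number seems the most reasonable expectation, with a wide margin on either side. The expected change is a 20-fold lower number from compound 3 to compound 4 (1.30 log units; beyond the scatter). For compound 4, the estimated value is 1500 nM, with an expected range of 200 nM to 10000 nM.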

Compound 4, concentration for 50% growth inhibition: 7000 nM
Beside the measured number, compound 4's estimate is 4.7-fold (0.67 log units) below it; the measured number falls inside the stated range.
By their numbers in this assay, from the lowest: compound 2; then compounds 4 and 1 (each within the scatter of the next); then compound 3.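

In this assay, 4-bromophenyl in place of 3,4-dihydroxyphenyl on the double-bonded ring carbon gives a 4.3-fold lower number from compound 3 to compound 4 (0.63 log units; beyond the scatter), so this exchange, which leaves no hydrogen-bond donors on the ring, brings only a modest shift. The comparison with the dimethyl analogue gives a 1.4-fold lower number from compound 1 to compound 4 (0.15 log units; within the scatter), which places these two compounds level, whereas a 35-fold higher number from compound 2 to compound 4 (1.54 log units; beyond the scatter) leaves the 4-fluoro-3-methylphenyl compound well apart from the bromo compound. Carrying a halogen on this aromatic ring is therefore not enough on its own to reach the low number of compound 2, and compound 4 is the compound that goes against any simple link between halogen and stronger inhibition of growth.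

Nothing available explains why these aromatic groups rank as they do. The compounds shown leave open whether the low number of compound 2 needs both the fluoro and the methyl, which a plain 4-fluorophenyl or 3-methylphenyl group would help to settle, and how an amine or a carboxylic acid on this ring would read in this assay.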